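Difluoro in Place of Fluoromethyl at the Acid Carbon

A few compounds are considered here, and "the series" means these few. Any claim that something is new, unique, unknown or untested is made for them only; others in the source may bear on it.

In a functional assay on HEK293 cells for agonist activity at Free fatty acid receptor 1 (Homo sapiens), read by FLIPR and calcium flux (on this read-out higher numbers stand for an effect only at larger amounts of compound and lower numbers for an effect already at smaller amounts), compound 1 `COc1ccc(F)c([C@H]2CC[C@H](COc3cccc([C@@H](CC(=O)O)C4CC4)c3)CC2)c1` gives 0.94 nM, compound 2 `COc1ccc(F)c([C@H]2CC[C@H](COc3cccc([C@H](C4CC4)[C@@H](F)C(=O)O)c3)CC2)c1` gives 1.1 nM, and compound 3 `COc1ccc(F)c([C@H]2CC[C@H](COc3cccc([C@H](C4CC4)[C@](C)(F)C(=O)O)c3)CC2)c1` gives 6.1 nM, the highest of the three numbers. Compound 4 `COc1ccc(F)c([C@H]2CC[C@H](COc3cccc([C@H](C4CC4)C(F)(F)C(=O)O)c3)CC2)c1` differs from compound 3 in one respect: carboxy(difluoro)methyl in place of 1-carboxy-1-fluoroethyl on a saturated chain carbon bound to an aromatic carbon and a saturated ring carbon. Among the measured compounds shown here, two measured steps bear on this change. The first, a 1.2-fold higher number from compound 1 to compound 2 (0.07 log units; within the scatter), stayed within the scatter; the second, a 5.5-fold higher number from compound 2 to compound 3 (0.74 log units; beyond the scatter), was a modest rise. Compound 4 drops the methyl whose arrival produced that rise and carries a second fluorine instead, so the account expects a 2.4-fold lower number from compound 3 to compound 4 (0.39 log units; beyond the scatter), a return towards the number of compound 2. Compound 4 is accordingly estimated at 2.5 nM, within a range from 0.8 nM to 8 nM.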

Compound 4, half-maximal effective concentration: 16 nM
The estimate for compound 4 lay 6.4-fold (0.81 log units) below the measured number; measured number outside the range, above it.
By their numbers in this assay, from the lowest: compounds 1 and 2 (each within the scatter of the next); then compound 3; then compound 4.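

In this assay, among the compounds shown here, carboxy(difluoro)methyl gives the highest number of the groups at this place, with a 17-fold higher number from compound 1 to compound 4 (1.23 log units; beyond the scatter) and a 15-fold higher number from compound 2 to compound 4 (1.16 log units; beyond the scatter) even though the single fluorine of compound 2 had stayed within the scatter of compound 1. Losing the methyl brought no return, as a 2.6-fold higher number from compound 3 to compound 4 (0.42 log units; beyond the scatter) shows that the second fluorine raises the number beyond what the methyl did. Nothing available explains this rise. The compounds shown leave open how a hydroxyl or a chlorine in place of the fluorine of compound 2 would read, and how a second methyl in place of the fluorine of compound 3 would.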